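Swapping the triazole substituent: from compound 3 to compound 4

This account rests on a few compounds, and the source may have more. Where it says the series, first, only, none or still open, it means among the compounds named here.

Measured so far:
- compound 1 `O=C1O/C(=C\Cn2cc(-c3cc(F)cc(F)c3)nn2)C(OCc2ccccc2)=C1OCc1ccccc1`: > 100000 nM
- compound 2 `CC(C)(C)OC(=O)N1CCN(C(=S)SCc2cn(C[C@H](O)[C@H]3OC(=O)C(OCc4ccccc4)=C3OCc3ccccc3)nn2)CC1`: > 100000 nM
- compound 3 `O=C1O[C@H]([C@@H](O)Cn2cc(CNS(=O)(=O)c3ccc(F)cc3)nn2)C(OCc2ccccc2)=C1OCc1ccccc1`: 22900 nM

Within the data shown here, in a functional assay on HCT-116 cells (Homo sapiens) for antiproliferative activity, read by MTT assay, with a stated time of 72 h (a lower number here means a stronger inhibitor, a higher number a weaker inhibitor), compound 3 is the only compound that gives a number. For compound 1 the value is a limit of the assay. For compound 2 the value is also a limit, so (the limit of > 100000 nM in this assay, at which 2 of the 3 values shown sit).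

Compound 4 `COc1ccc(-c2cn(C[C@H](O)[C@H]3OC(=O)C(OCc4ccccc4)=C3OCc3ccccc3)nn2)cc1` has not been measured. It differs from compound 3 in one place: 4-methoxyphenyl in place of (((4-fluorophenyl)sulfonyl)amino)methyl on an aromatic carbon.

Among the measured compounds shown here, since no measured pair shows this kind of change, the step from compound 3 to compound 4 is estimated only loosely; a modest loss of activity is expected, a 2.2-fold higher number from compound 3 to compound 4 (0.34 log units; beyond the scatter). For compound 4 the expected value in this assay is 50000 nM, within 15000 nM to 150000 nM.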

Compound 4, half-maximal inhibitory concentration: > 100000 nM
Compound 4: a limit, no number; the forecaster's own chance of this, stated with the estimate: 40%; at least 2.0-fold (0.30 log units) between middle value and limit.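

In this assay, this position on the triazole turns out to be sensitive: 4-methoxyphenyl in place of (((4-fluorophenyl)sulfonyl)amino)methyl gives an at least 4.3-fold higher number from compound 3 to compound 4 (0.64 log units; beyond the scatter). Among these compounds, this is the first direct comparison of two compounds that differ in one place, and it links the measurable activity of compound 3 to the group it loses here. The true size of the step stays unknown, as compound 4 sits at a limit shared by most compounds shown: the limit of > 100000 nM in this assay, at which 3 of the 4 values shown sit.

Which part of the leaving group matters, the sulfonyl amino link or the fluorophenyl ring, remains open. As far as these compounds go, how a plain aminomethyl group or a carboxylic acid would behave at this carbon is also open.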